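Swapping Iodo for Trifluoromethyl on the Aryl Triazole

A few compounds are considered here, and "the series" means these few. Any claim that something is new, unique, unknown or untested is made for them only; others in the source may bear on it.

Compound 3 `O=C(Nc1cccc(OCc2cn(-c3ccccc3I)nn2)c1)Nc1ccc(Cl)c(C(F)(F)F)c1` gives 2870 nM in a functional assay on HepG2 cells (Homo sapiens) for inhibition, read by MTT assay, with a stated time of 72 h (on this read-out higher numbers stand for weaker inhibition and lower numbers for stronger inhibition), the highest of the three numbers shown, although its gaps to compound 1 `CCc1ccc(-n2cc(COc3cccc(NC(=O)Nc4ccc(Cl)c(C(F)(F)F)c4)c3)nn2)cc1` with 1950 nM and to compound 2 `O=C(Nc1cccc(OCc2cn(-c3ccccc3F)nn2)c1)Nc1ccc(Cl)c(C(F)(F)F)c1` with 1520 nM both lie within the scatter. Compound 4 `O=C(Nc1cccc(OCc2cn(-c3ccccc3C(F)(F)F)nn2)c1)Nc1ccc(Cl)c(C(F)(F)F)c1` differs from compound 3 by trifluoromethyl in place of iodo on an aromatic carbon. Within the data shown here, the steps that bear on this position were a 1.9-fold higher number from compound 2 to compound 3 (0.28 log units; within the scatter) and a 1.5-fold higher number from compound 1 to compound 3 (0.17 log units; within the scatter), together with a 1.3-fold lower number from compound 1 to compound 2 (0.11 log units; within the scatter), none of them beyond the scatter; each change made so far on that aryl group has left the read-out essentially in place. A step of about a 1.1-fold lower number from compound 3 to compound 4 (0.06 log units; within the scatter) is therefore expected, which means none beyond the scatter. Compound 4 is estimated at 2500 nM, with a range from 1200 nM to 5500 nM.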

Compound 4, half-maximal inhibitory concentration: 2320 nM
Compound 4: middle estimate off by 1.1-fold (0.03 log units), on the high side; the range from low to high includes it.
By their numbers in this assay, from the lowest: compounds 2, 1, 4 and 3 (each within the scatter of the next).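

Trifluoromethyl, with four heavy atoms, takes the place of the single iodine atom and the read-out in this assay stays within the scatter (a 1.2-fold lower number from compound 3 to compound 4 (0.09 log units; within the scatter)). The same holds against the fluoro compound (a 1.5-fold higher number from compound 2 to compound 4 (0.18 log units; within the scatter)) and the ethyl compound (a 1.2-fold higher number from compound 1 to compound 4 (0.08 log units; within the scatter)), so all four aryl groups shown on the triazole nitrogen now give numbers that cannot be told apart. No measurement at hand accounts for this flat read-out. The compounds shown leave open whether an amine or a carboxylic acid on that six-membered aromatic ring would move the number beyond the scatter.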